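The source may report more compounds than this note shows. Statements on the series, on what has been measured and on what is new or still open speak of the compounds shown alone.

Compounds measured so far:
compound 1 `Cn1ccc2cc(-c3cc4nccc(-c5ccc(F)cc5)n4n3)ccc21` gives 4780 nM
compound 2 `COc1ccc(-c2cc3nccc(-c4cc(OC)c(OC)c(OC)c4)n3n2)cc1F` gives 3950 nM
compound 3 `CCOC(=O)c1ccc(-c2cc3nccc(-c4cc(OC)c(OC)c(OC)c4)n3n2)cc1` gives > 10000 nM

In a functional assay on B16-F0 cells (Mus musculus) for inhibition, read by CCK-8 assay, with a stated time of 48 h (on this read-out lower numbers stand for stronger inhibition and higher numbers for weaker inhibition), compound 2 has the lowest of the two numbers, yet compound 1 sits within the usual scatter of it, so the two cannot be told apart. For compound 3 the result in this assay is a limit of the assay and not a number, as stated in the limit of > 10000 nM in this assay, at which 1 of the 3 values shown sits. Compound 4 `COc1cc(-c2ccnc3cc(-c4cccc(C#N)c4)nn23)cc(OC)c1OC` is not yet measured. Its change from compound 2 is 3-cyanophenyl in place of 3-fluoro-4-methoxyphenyl on an aromatic carbon. Within the data shown here, no comparable step has been measured here, so the size of the step is uncertain; a modest weakening or none beyond the scatter seems the likelier outcome. For compound 4 the expected result in this assay is 6000 nM, ranging from 2000 nM to 20000 nM, a step of a 1.5-fold higher number from compound 2 to compound 4 (0.18 log units; within the scatter) that is estimated, not known.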

Compound 4, half-maximal inhibitory concentration: > 10000 nM
Compound 4: no number, only a limit; the forecaster's own chance of this, stated with the estimate: 35%; at least 1.6-fold (0.22 log units) between middle value and limit.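

Among these compounds, the first measured step at this position, on the five-membered aromatic ring, shows that the group here is not freely exchangeable: 3-cyanophenyl in place of 3-fluoro-4-methoxyphenyl gives an at least 2.5-fold higher number from compound 2 to compound 4 (0.40 log units; beyond the scatter) in this assay on the same core. The result for compound 4 is a limit of the assay and not a number: the limit of > 10000 nM in this assay, at which 2 of the 4 values shown sit.

As far as these compounds go, the step swaps the fluorine, the methoxy and the nitrile together, so which of them counts stays open. From the compounds shown here alone, whether a phenyl ring carrying an amine or a carboxylic acid here would give a lower number also stays open.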